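A few compounds are considered here, and "the series" means these few. Any claim that something is new, unique, unknown or untested is made for them only; others in the source may bear on it.

Compound 1, `Cc1ccccc1Cn1cc(COc2ccc3c(=O)ccoc3c2)nn1`: in a functional assay on SGC-7901 cells (Homo sapiens) for cytotoxicity, read by MTT assay, with a stated time of 48 h (a lower number here means a stronger inhibitor, a higher number a weaker inhibitor), compound 1 gives > 100000 nM, a limit of the assay.
Compound 2, `O=c1ccoc2cc(OCc3cn(Cc4ccc(F)cc4)nn3)ccc12`: in this assay compound 2 gives > 100000 nM, likewise a limit.

Compound 2 thus stands only at a limit, with no number of its own. Both readings share (the limit of > 100000 nM in this assay, at which 2 of the 2 values shown sit). Compound 3, `O=c1ccoc2cc(OCc3cn(Cc4ccccc4Br)nn3)ccc12`, differs from compound 2 by 2-bromophenyl in place of 4-fluorophenyl on a saturated chain carbon bound to an aromatic nitrogen. Among the measured compounds shown here, the single measured step on a change of this kind, a step that the two limits leave unreadable from compound 1 to compound 2, gives no readable size, so neither direction nor magnitude can be drawn for this assay. Compound 3 is expected to sit at 150000 nM, within 50000 nM to 500000 nM, most likely again as a limit. The estimated step that the limit leaves unreadable from compound 2 to compound 3 is expected to be nothing beyond scatter.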

Compound 3, half-maximal inhibitory concentration: > 100000 nM
Compound 3 was reported as a limit; the forecaster's own chance of this, stated with the estimate: 85%; the middle value does not contradict the limit.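

Compound 3 sits at a limit, as do compound 1 and compound 2, so no step among them can be read in this assay: the limit of > 100000 nM in this assay, at which 3 of the 3 values shown sit.

The compounds shown leave open whether 2-methylphenyl, 4-fluorophenyl and 2-bromophenyl differ at all in cytotoxicity.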